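Replacing carbamoyl with hydroxy: the step to compound 4

The source may report more compounds than this note shows. Statements on the series, on what has been measured and on what is new or still open speak of the compounds shown alone.

Compound 1 `CSc1ccc(NC(=O)Nc2cc(C)nc3ccccc23)cc1`: > 25000 nM
Compound 2 `COC(=O)c1ccc(NC(=O)Nc2cc(C)nc3ccccc23)cc1`: 17000 nM
Compound 3 `Cc1cc(NC(=O)Nc2ccc(C(N)=O)cc2)c2ccccc2n1`: > 25000 nM

All three were tested in an ADME assay on Raji cells (Homo sapiens) for cytotoxicity, with a stated time of 72 h; on this read-out lower numbers stand for an effect already at smaller amounts and higher numbers for an effect only at larger amounts of compound. Compound 3 stands at the limit of > 25000 nM in this assay, at which 2 of the 3 values shown sit. Compound 1 shares that limit, while compound 2 alone has a number.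

Compound 4 `Cc1cc(NC(=O)Nc2ccc(O)cc2)c2ccccc2n1` carries hydroxy in place of carbamoyl on an aromatic carbon, para to a large group (hydroxy in place of carbamoyl on an aromatic carbon). Among the compounds with values here, no measured step makes this exchange. The nearest evidence is an at least 1.4-fold lower number from compound 1 to compound 2 (0.16 log units; that floor lies within the scatter), together with an at least 1.4-fold higher number from compound 2 to compound 3 (0.16 log units; that floor lies within the scatter), and a step that the two limits leave unreadable from compound 1 to compound 3 adds no readable size. No step beyond the scatter is therefore expected, in either direction. The estimate implies an at least 1.1-fold lower number from compound 3 to compound 4 (0.05 log units; that floor lies within the scatter), as an expected step. Compound 4 is expected near 22000 nM, with an estimated range from 10000 nM to 45000 nM.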

Compound 4, half-maximal effective concentration: > 25000 nM
Compound 4 gave a limit, no number (the forecaster's own chance of this, stated with the estimate: 60%); middle value at least 1.1-fold (0.05 log units) away from the limit.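

In this assay compound 4 gives > 25000 nM, which is a limit and not a number. Hydroxy on this aromatic carbon thus sits with methylsulfanyl and carbamoyl at one shared limit: the limit of > 25000 nM in this assay, at which 3 of the 4 values shown sit. Within the data shown here, the only readable new step is an at least 1.4-fold higher number from compound 2 to compound 4 (0.16 log units; that floor lies within the scatter), and the other two new steps cannot be read, since each joins two limits.

From the compounds shown here alone, how far compound 1, compound 3 and compound 4 differ from each other remains open. So does whether an amine or a carboxylic acid on this aromatic carbon would give a number in this assay.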